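The source may report more compounds than this note shows. Statements on the series, on what has been measured and on what is new or still open speak of the compounds shown alone.

Of the compounds shown here, two have so far been measured in a functional assay on DU-145 cells (Homo sapiens) for inhibition, read by MTT assay, with a stated time of 24 h; a higher number here means a weaker inhibitor, a lower number a stronger inhibitor. Compound 1 `CCOC(=O)C1=Cc2ccccc2OC1(OCc1cn(-c2ccc(F)cc2)nn1)C(F)(F)F` gives 8900 nM in this assay, the lower of the two numbers. Compound 2 `O=C(O)C1=Cc2ccccc2OC1(OCc1cc(-c2ccc(F)cc2)no1)C(F)(F)F` differs from compound 1 in several places; in this assay compound 2 gives 168000 nM. The gap between these two numbers lies beyond the usual scatter, so compound 1 stands as the stronger inhibitor of the pair. Compound 3 `CCOC(=O)C1=Cc2ccccc2OC1(OCc1cn(-c2cccc(C(F)(F)F)c2)nn1)C(F)(F)F` has not yet been measured. It differs from compound 1 in a single place: 3-(trifluoromethyl)phenyl in place of 4-fluorophenyl on an aromatic nitrogen. For the measured compounds named here, no measured pair shows the effect of this particular change, so there is no step to lean on. Since compound 1 gives 8900 nM in this assay and the shared core is left untouched, the expectation is a step of a 1.0-fold higher number from compound 1 to compound 3 (0.00 log units; within the scatter) that stays within the usual scatter, in either direction. Compound 3 is therefore estimated at 9000 nM in this assay, with a range from 3000 nM to 30000 nM. That range is kept wide. Going by these compounds, the change itself is untested among the measured compounds.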

Compound 3, half-maximal inhibitory concentration: > 150000 nM
Compound 3 was reported as a limit; the forecaster's own chance of this, stated with the estimate: 5%; at least 16-fold (1.22 log units) between middle value and limit.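

For the compounds shown here, the group on the aromatic nitrogen of the five-membered ring with 3 nitrogen matters far more than the single untested swap suggested: with the shared core left untouched, 3-(trifluoromethyl)phenyl in place of 4-fluorophenyl gives an at least 16-fold higher number from compound 1 to compound 3 (1.22 log units; beyond the scatter) in this assay. Compound 1 and compound 2 differ in several places, so that pair could not tie any change in inhibition to this one position, whereas this step does. The step is only a lower bound, since compound 3 is reported as a limit of the assay and not as a number: the limit of > 150000 nM in this assay, at which 1 of the 3 values shown sits.

This single swap changes two things at once, the group on the phenyl ring and where on that ring it sits, so the compounds shown cannot say which of the two matters. A 4-(trifluoromethyl)phenyl or a 3-fluorophenyl group on the same nitrogen would separate the two, and a plain phenyl group would show how the 4-fluorophenyl of compound 1 compares with no added group at all.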